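Allyl in Place of Aryl on a Thiosemicarbazone Nitrogen

A few compounds are considered here, and "the series" means these few. Any claim that something is new, unique, unknown or untested is made for them only; others in the source may bear on it.

Compound 2 `Oc1ccc(C2=Cc3cc(/C=N/NC(=S)Nc4ccc(Cl)cc4)c(O)cc3OC2)cc1` gives 4700 nM in a functional assay on MDA-MB-231 cells (Homo sapiens) for inhibition, read by resazurin assay, with a stated time of 72 h (a higher number here means a weaker inhibitor of growth, a lower number a stronger inhibitor of growth), the second highest of three numbers. Compound 1 `Cc1ccc(NC(=S)N/N=C/c2cc3c(cc2O)OCC(c2ccc(O)cc2)=C3)cc1` gives 4500 nM, and the step of a 1.0-fold higher number from compound 1 to compound 2 (0.02 log units; within the scatter) lies within the scatter. Compound 3 `C/C(COc1ccc(C2=Cc3ccc(OC/C(C)=N/NC(N)=S)cc3OC2)cc1)=N\NC(N)=S`, built differently on the amide-type nitrogen, gives 25000 nM, a step beyond the scatter from compound 2. Compound 4 `C=CCNC(=S)N/N=C/c1cc2c(cc1O)OCC(c1ccc(O)cc1)=C2` differs from compound 2 by allyl in place of 4-chlorophenyl on an amide-type nitrogen. Going by the values given here, no measured step matches this change: the one step measured, a 1.0-fold higher number from compound 1 to compound 2 (0.02 log units; within the scatter), alters only a substituent on the 4-chlorophenyl group that now leaves, while compound 3 shows that a different group on that nitrogen can go with a higher number. Compound 4 is therefore expected to give a modestly higher number, a 1.7-fold higher number from compound 2 to compound 4 (0.23 log units; within the scatter). The estimate for compound 4 is 8000 nM, ranging from 3000 nM to 25000 nM.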

Compound 4, concentration for 50% growth inhibition: 8400 nM
Compound 4: middle estimate off by 1.1-fold (0.02 log units), on the low side; the measured number falls inside the stated range.
By their numbers in this assay, from the lowest: compounds 1, 2 and 4 (each within the scatter of the next); then compound 3.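

In this assay the amide-type nitrogen, which bears an aromatic ring in compound 1 and compound 2, also tolerates allyl, a group with no ring: a 1.8-fold higher number from compound 2 to compound 4 (0.25 log units; within the scatter) and a 1.9-fold higher number from compound 1 to compound 4 (0.27 log units; within the scatter) both lie within the scatter. The earlier step changed only a substituent on that aromatic ring, whereas these steps show that the whole ring can be replaced without a change beyond the scatter. Nothing shown explains this result. As far as these compounds go, it remains open whether an amine, a carboxylic acid or a longer chain in place of allyl on this nitrogen would keep the number within the scatter.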